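Compound 3: one group changes at a clearance limit

The source may report more compounds than this note shows. Statements on the series, on what has been measured and on what is new or still open speak of the compounds shown alone.

Compound 1 `C[C@H](c1ccc(F)cc1)N(Cc1cccc(C(=O)O)c1)C(=O)c1cc2ccccn2n1` gives 42 mL.min-1.g-1
Compound 2 `C[C@H](c1ccc(F)cc1)N(Cc1cccc(C(=O)O)c1)C(=O)c1cc2ccccc2nn1` gives < 8 mL.min-1.g-1

In an ADME assay (liver) for metabolic stability, with Liver microsome (Homo sapiens) as the target, using microsomes (on this read-out lower numbers stand for slow clearance and higher numbers for fast clearance), compound 1 gives 42 mL.min-1.g-1 as a plain number. Compound 2 gives < 8 mL.min-1.g-1 in this assay and this is a limit, not a number. Compound 2 thus stands at the limit of < 8 mL.min-1.g-1 in this assay, at which 1 of the 2 values shown sits, and has no exact place on the scale.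

Compound 3 `C[C@H](c1ccc(F)cc1)N(Cc1cccc(C(=O)O)c1)C(=O)c1cc2ccccc2cn1` keeps the shared core and changes one group: a group of 10 heavy atoms (9 carbon, 1 nitrogen; one six-membered aromatic ring of carbon only, one six-membered aromatic ring with 1 hetero atom) in place of a group of 10 heavy atoms (8 carbon, 2 nitrogen; one six-membered aromatic ring of carbon only, one six-membered aromatic ring with 2 hetero atoms), on a carbonyl carbon and isoquinolin-3-yl is the group that enters, on a carbonyl carbon.

Among the compounds with values here, only one measured step bears on this change. It sits on the same carbonyl carbon but swaps a different pair of groups: an at least 5.2-fold lower number from compound 1 to compound 2 (0.72 log units; beyond the scatter) and so a change at this place can matter. With that single step as the guide, a smaller move upward from compound 2 is expected in this assay and it may stay within the usual scatter. The expected change is an at least 1.6-fold higher number from compound 2 to compound 3 (0.21 log units; that floor lies within the scatter) and no more than that. The estimate for compound 3 is 13 mL.min-1.g-1 with an expected range from 6 mL.min-1.g-1 to 30 mL.min-1.g-1 in this read-out.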

Compound 3, intrinsic clearance in microsomes in the Liver microsome assay: 16 mL.min-1.g-1
Beside the measured number, compound 3's estimate is 1.2-fold (0.09 log units) below it; low and high end bracket the measured number.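

In the Liver microsome assay compound 3 gives 16 mL.min-1.g-1 as a plain number on this carbonyl carbon, so the position now has two exact readings rather than one. These readings confirm, with no limit involved, that the group here can shift the read-out, the step being a 2.6-fold lower number from compound 1 to compound 3 (0.42 log units; beyond the scatter). Isoquinolin-3-yl and the group it replaces in compound 2 are the same size, with 10 heavy atoms each, and differ only in that one ring nitrogen gives way to carbon; the step is an at least 2.0-fold higher number from compound 2 to compound 3 (0.30 log units; that floor lies within the scatter), and since that floor does not clear the scatter, it does not show that this small swap matters, while the true size of the step stays unknown because compound 2 has only a limit: the limit of < 8 mL.min-1.g-1 in the Liver microsome assay, at which 1 of the 3 values shown sits.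

Going by these compounds, whether a plain phenyl ring or a pyridin-2-yl group on this carbonyl carbon would read closer to compound 1 or to compound 3 remains open, as does how much of the read-out depends on the second ring of these groups. In a physicochemical assay for lipophilicity (on this read-out higher numbers stand for higher lipophilicity and lower numbers for lower lipophilicity), the entry for compound 2 reads "not determined" (no result reported). In the physicochemical assay compound 3 gives 1.1, and with no second value shown there, that number cannot yet be compared with any other compound.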